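This account rests on a few compounds, and the source may have more. Where it says the series, first, only, none or still open, it means among the compounds named here.

In a functional assay on HeLa cells (Homo sapiens) for inhibition, read by sulforhodamine B assay, with a stated time of 48 h (a higher number here means a weaker inhibitor of growth, a lower number a stronger inhibitor of growth), compound 1 `O=C(/C=C/c1c(Cl)nc2ccccn12)N1CCC=CS1(=O)=O` gives 8200 nM, and compound 2 `O=C(/C=C/c1ccccc1F)N1CCC=CS1(=O)=O` gives 13700 nM. Compound 3 `O=C(/C=C/c1cccc(F)c1)N1CCC=CS1(=O)=O` is reported only as a limit of the assay, < 100 nM, the point at which (the limit of < 100 nM in this assay, at which 1 of the 3 values shown sits). So the true value of compound 3 is not known, only that it sits at this limit. Compound 4 `O=C(/C=C/c1cccc(C(F)(F)F)c1)N1CCC=CS1(=O)=O` has not yet been measured; it differs from compound 3 by trifluoromethyl in place of fluoro on an aromatic carbon. Within the data shown here, no pair of measured compounds shows this change, so its effect in this assay cannot be read from the numbers at hand. The expected step is small, roughly within the usual scatter: an at least 1.5-fold higher number from compound 3 to compound 4 (0.17 log units; that floor lies within the scatter). On that basis compound 4 is estimated at 150 nM, with a range from 30 nM to 1500 nM.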

Compound 4, concentration for 50% growth inhibition: 19600 nM
The estimate for compound 4 lay 130-fold (2.12 log units) below the measured number; measured number outside the range, above it.
By their numbers in this assay, from the lowest: compounds 1, 2 and 4 (each within the scatter of the next, the first and the last beyond it). At a limit, below all of these: compound 3.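

At this aromatic carbon, meta to a large group, putting trifluoromethyl in place of fluoro gives an at least 190-fold higher number from compound 3 to compound 4 (2.29 log units; beyond the scatter) and turns a compound at the strong end of the series into a weak one. Among these compounds, no earlier pair of compounds showed what one change in one place does. On these data alone, the true size of this step remains unknown, since compound 3 is reported only as a limit: the limit of < 100 nM in this assay, at which 1 of the 4 values shown sits.

As far as these compounds go, whether a methyl or a chlorine at this same carbon would stay close to compound 3 or to compound 4 remains open. So does the effect of an amine there.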